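The source may hold more compounds than are shown below. What is called first, only, known or untested is meant among the compounds shown, and "the series" means these compounds.

Compound 1 `COc1ccc(-c2c(C)nc3c(N4CC[C@@H](NC(C)=O)C4)cc(C)nn23)cc1OC`: > 95%
Compound 2 `CC(=O)N[C@@H]1CCN(c2cc(C)nn3c(-c4ccccc4)c(C)nc23)C1`: > 95%
Compound 3 `CC(=O)N[C@@H]1CCN(c2cc(C)nn3c(-c4ccc(C#N)cc4)c(C)nc23)C1`: > 95%

In an ADME assay on microsomes from liver (Homo sapiens) for metabolic stability, read by LC-MS, with NADPH named in the record, with a stated time of 60 min, tested at 1 uM, in the absence of a further agent (on this read-out lower numbers stand for a less stable compound and higher numbers for a more stable compound), compound 1 gives > 95%, which is a limit and not a number. The other measured compounds offer no contrast: the limit of > 95% in this assay, at which 3 of the 3 values shown sit. Compound 4 `COc1ccc(-c2c(C)nc3c(N4CC[C@@H](NC(=O)COc5ccccc5)C4)cc(C)nn23)cc1OC` keeps the core of compound 1 and changes only the side chain: phenoxy in place of hydrogen on a saturated chain carbon bound to a carbonyl carbon. Acetamido thus becomes ((phenoxymethyl)carbonyl)amino. The measured steps, a step that the two limits leave unreadable from compound 1 to compound 2, a step that the two limits leave unreadable from compound 1 to compound 3 and a step that the two limits leave unreadable from compound 2 to compound 3, all concern an aromatic carbon rather than this chain, and none has a readable size. The estimate therefore starts from compound 1 at > 95% and is a cautious one. A moderate fall is expected, a number at least 20 percentage points lower from compound 1 to compound 4 (beyond the scatter). For compound 4 the expected value is 75%, with an estimated range of 45% to 95%.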

Compound 4, percent of the compound remaining: > 95%
Compound 4: no number, only a limit; the forecaster's own chance of this, stated with the estimate: 25%; middle value at least 20 percentage points away from the limit.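

Going by these compounds alone, compound 1 and compound 4 both give only a limit and not a number, so no step between them can be read: the limit of > 95% in this assay, at which 4 of the 4 values shown sit. The compounds shown leave open whether adding phenoxy to the side chain changes stability at all.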